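From hydroxy to dimethylamino on the side chain

The compounds below may be only part of what the source reports. "The series", "measured", "known", "first", "only" and "open" are said of these compounds alone.

Values in a functional assay on A2780 cells (Homo sapiens) for antiproliferative activity, read by MTT assay, with a stated time of 48 h (a higher number here means a weaker inhibitor, a lower number a stronger inhibitor), are as follows
Compound 1 `C=C(c1cc(OC)c(OC)c(OC)c1)c1ccc(OC)cc1NC(=O)CO` gives 30 nM 
Compound 2 `C=C(c1ccc(OC)cc1NC(=O)CNCC)c1ccc(OC)c2c1C=CC(C)(C)O2` gives 2010 nM 

Compound 1 at 30 nM holds the lower of the two numbers, and compound 2 at 2010 nM lies beyond the scatter from it. Compound 3 `C=C(c1cc(OC)c(OC)c(OC)c1)c1ccc(OC)cc1NC(=O)CN(C)C` keeps the core of compound 1 and carries dimethylamino in place of hydroxy on a saturated chain carbon bound to a carbonyl carbon. Within the data shown here, no measured pair shows this change, so only a small rise of the number in this assay is expected. The estimated 2.3-fold higher number from compound 1 to compound 3 (0.37 log units; beyond the scatter) points toward a weaker inhibitor, close to the scatter. For compound 3 the expected value is 70 nM (range 20 nM to 300 nM).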

Compound 3, half-maximal inhibitory concentration: 240 nM
For compound 3 the middle estimate is 3.4-fold (0.54 log units) below the measured one; the measured number falls inside the stated range.
By their numbers in this assay, from the lowest: compound 1; then compound 3; then compound 2.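

In this assay this place on the side chain proves sensitive: dimethylamino in place of hydroxy gives an 8.0-fold higher number from compound 1 to compound 3 (0.90 log units; beyond the scatter), a modest step beyond the scatter. The change weakens compound 3 on the core of compound 1 without abolishing its activity. Nothing available explains this loss. The compounds shown leave open whether it follows from losing hydroxy or from introducing dimethylamino. On the same core, methoxy or a primary amine at this place could help to separate these two readings.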